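The source may hold more compounds than are shown below. What is called first, only, known or untested is meant among the compounds shown, and "the series" means these compounds.

Measured compounds:
compound 1 `O=C(O)c1ccc(-c2cnc(C(=O)CCc3ccc(Oc4ccccc4)cc3)o2)nc1`, 33 nM in an assay for inhibition of Fatty-acid amide hydrolase 1 (Rattus norvegicus); on this read-out lower numbers stand for stronger inhibition and higher numbers for weaker inhibition;
compound 2 `COC(=O)c1ccc(-c2cnc(C(=O)CCc3ccc(Oc4ccccc4)cc3)o2)nc1`, 54 nM in this assay;
compound 3 `CNC(=O)c1cnc(C(=O)CCc2ccc(Oc3ccccc3)cc2)o1`, 11 nM in this assay.

Compound 3 gives the lowest number of the three and is the most potent here; the steps of a 3.0-fold lower number from compound 1 to compound 3 (0.48 log units; beyond the scatter) and a 4.9-fold lower number from compound 2 to compound 3 (0.69 log units; beyond the scatter) are both beyond the scatter, whereas a 1.6-fold higher number from compound 1 to compound 2 (0.21 log units; within the scatter) is not. Compound 4 `O=C(CCc1ccc(Oc2ccccc2)cc1)c1ncc(C(F)(F)F)o1` is unmeasured. Against compound 3 the change is trifluoromethyl in place of methylcarbamoyl on an aromatic carbon. Within the data shown here, no measured step makes this exact exchange; the two steps that touch the same aromatic carbon were modest and each favoured methylcarbamoyl over the larger group, so a modest rise in the number, if any, is expected from compound 3 to compound 4 in this assay, roughly a 2.7-fold higher number from compound 3 to compound 4 (0.44 log units; beyond the scatter). Compound 4 is therefore estimated at 30 nM, within about 8 nM to 120 nM.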

Compound 4, inhibition constant: 2 nM
Estimate against measurement, compound 4: 15-fold (1.18 log units) above; the measured number lies below the stated range.
By their numbers in this assay, from the lowest: compound 4; then compound 3; then compounds 1 and 2 (each within the scatter of the next).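

In this assay, methylcarbamoyl is no longer the best group shown on the aromatic carbon next to the ring oxygen: trifluoromethyl, with 0 hydrogen-bond donors and 0 hydrogen-bond acceptors, gives a further drop (a 5.5-fold lower number from compound 3 to compound 4 (0.74 log units; beyond the scatter)), so a hydrogen-bond donor or acceptor in this group is not required for a low number. The gaps to the pyridinyl-bearing groups are large (a 27-fold lower number from compound 2 to compound 4 (1.43 log units; beyond the scatter); a 17-fold lower number from compound 1 to compound 4 (1.22 log units; beyond the scatter)). No supporting data explain this result.

From the compounds shown here alone, it remains open whether a nitrile, a methyl or a chlorine here would match trifluoromethyl, so what this position requires is still undefined.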